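Adding a Second Methoxy to Compound 2

The source may report more compounds than this note shows. Statements on the series, on what has been measured and on what is new or still open speak of the compounds shown alone.

Within the data shown here, in a functional assay on A549 cells (Homo sapiens) for inhibition, read by MTT assay, with a stated time of 24 h (a higher number here means a weaker inhibitor of growth, a lower number a stronger inhibitor of growth), compound 1 `COc1ccc2c(c1)c(-c1nc3ccccc3n1C(=O)c1ccccc1)cn2C` gives 16700 nM, while compound 2 `COc1ccc(C(=O)n2c(-c3cn(C)c4ccc(OC)cc34)nc3ccccc32)cc1` gives 4900 nM, the lower of the two numbers so far. Compound 3 `COc1ccc2c(c1)c(-c1nc3ccccc3n1C(=O)c1ccc(OC)c(OC)c1)cn2C` turns the 4-methoxyphenyl group of compound 2 into 3,4-dimethoxyphenyl: methoxy in place of hydrogen on an aromatic carbon. Among the measured compounds shown here, only one measured step bears on this, the same kind of swap, a 3.4-fold lower number from compound 1 to compound 2 (0.53 log units; beyond the scatter). A single step is thin evidence, so a smaller move in the same direction is expected, possibly none beyond the scatter. The estimated change is a 1.4-fold lower number from compound 2 to compound 3 (0.15 log units; within the scatter). Compound 3 is expected at 3500 nM, with an estimated range of 1300 nM to 10000 nM.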

Compound 3, concentration for 50% growth inhibition: 2700 nM
The estimate for compound 3 lay 1.3-fold (0.11 log units) above the measured number, and the stated range covers the measured number.
By their numbers in this assay, from the lowest: compounds 3 and 2 (each within the scatter of the next); then compound 1.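

Adding a methoxy ortho to a methoxy group, 4-methoxyphenyl to 3,4-dimethoxyphenyl, gives a 1.8-fold lower number from compound 2 to compound 3 (0.26 log units; within the scatter), so this second methoxy cannot be distinguished from hydrogen in this assay. Counted from the unsubstituted phenyl, the two methoxy groups together give a 6.2-fold lower number from compound 1 to compound 3 (0.79 log units; beyond the scatter), a gain that the single added group here does not establish on its own. Nothing available explains these numbers. On these data alone, whether an amine, a hydroxyl or a longer chain such as ethoxy at this position would shift the number remains open. So does whether the 3-methoxyphenyl group alone would match the 3,4-dimethoxyphenyl group.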